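A few compounds are considered here, and "the series" means these few. Any claim that something is new, unique, unknown or untested is made for them only; others in the source may bear on it.

Compound 1, `COC(=O)/C=C/c1cccc2c1N(Cc1ccc(OC)cc1)C(=O)C2=O`, gives > 10000 nM in a functional assay on HT-29 cells (Homo sapiens) for cytotoxicity, read by MTT assay, with a stated time of 48 h; on this read-out lower numbers stand for stronger inhibition and higher numbers for weaker inhibition.
Compound 2, `COc1ccc(CN2C(=O)C(=O)c3cc(/C=C/C(=O)OCCO)ccc32)cc1`, gives 550 nM in this assay.
Compound 3, `COC(=O)/C=C/c1ccc2c(c1)C(=O)C(=O)N2Cc1ccc(Cl)c(Cl)c1`, gives 210 nM in this assay.

The value of compound 1 is a limit of the assay rather than a number, as the limit of > 10000 nM in this assay, at which 1 of the 3 values shown sits, records. Of the two numbers available, compound 2 stands at the higher one, with compound 3 at a lower number that lies beyond the usual scatter.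

Compound 4, `COc1ccc(CN2C(=O)C(=O)c3cc(/C=C/C(=O)N4CCCC4)ccc32)cc1`, has not yet been measured in this assay. It differs from compound 2 in a single place: pyrrolidin-1-yl in place of 2-hydroxyethoxy on a carbonyl carbon. Among the measured compounds shown here, no pair of measured compounds shares this change, so no measured step can guide its size or direction. The step of a 1.2-fold lower number from compound 2 to compound 4 (0.09 log units; within the scatter) is expected to be small, likely within the usual scatter and with no clear direction. The estimate for compound 4 in this assay is 450 nM, expected to fall between 130 nM and 1600 nM.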

Compound 4, half-maximal inhibitory concentration: 5230 nM
Compound 4: middle estimate off by 12-fold (1.07 log units), on the low side; the measured number lies above the stated range.
By their numbers in this assay, from the lowest: compound 3; then compound 2; then compound 4. At a limit, above all of these: compound 1.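

Among the compounds shown here, the group on this carbonyl carbon turns out to matter for the cytotoxic read-out in this assay: pyrrolidin-1-yl in place of 2-hydroxyethoxy gives a 9.5-fold higher number from compound 2 to compound 4 (0.98 log units; beyond the scatter), a change the earlier compounds could not show, since none of them formed a single-place pair. The position therefore does not tolerate every group equally, and in this one pair the change from 2-hydroxyethoxy to pyrrolidin-1-yl weakens the effect on the cells. Nothing given here accounts for the size of this step.

From the compounds shown here alone, it remains open whether the loss follows the nitrogen on the carbonyl carbon, the ring, or the missing hydroxyl. A 2-hydroxyethylamino group, an open-chain diethylamino group or a carboxylic acid at the same carbonyl carbon would begin to separate these.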